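Compound 3 to compound 4: a 4-methoxyphenyl swap

The source may report more compounds than this note shows. Statements on the series, on what has been measured and on what is new or still open speak of the compounds shown alone.

In an ADME assay on Vero cells (Chlorocebus sabaeus) for cytotoxicity, read by MTT assay (on this read-out higher numbers stand for weaker inhibition and lower numbers for stronger inhibition), compound 1 `C=CCOc1cc(OC)c(C(=O)/C=C/c2ccccc2)c(OCC=C)c1` gives 17100 nM, compound 2 `C=CCOc1cc(OC)c(C(=O)/C=C/c2ccc(C(F)(F)F)cc2)c(OCC=C)c1` gives 7200 nM, and compound 3 `C=CCOc1cc(OC)c(C(=O)/C=C/c2ccccc2F)c(OCC=C)c1` gives 16300 nM. Compound 3 therefore belongs to the upper pair of these three numbers. Within the data shown here, two measured steps bear on the next change: fluoro in place of hydrogen gave a 1.0-fold lower number from compound 1 to compound 3 (0.02 log units; within the scatter), and trifluoromethyl in place of hydrogen gave a 2.4-fold lower number from compound 1 to compound 2 (0.38 log units; beyond the scatter). The swap back to the group of compound 2 gave a 2.3-fold higher number from compound 2 to compound 3 (0.35 log units; beyond the scatter). Compound 4 `C=CCOc1cc(OC)c(C(=O)/C=C/c2ccc(OC)cc2)c(OCC=C)c1` differs from compound 3 as follows: 4-methoxyphenyl in place of 2-fluorophenyl on a double-bonded chain carbon bound to a double-bonded chain carbon. Among the measured compounds shown here, no measured compound carries a methoxy group on this phenyl ring, so the steps offer only a modest guide. The expected result in this assay is a 1.2-fold lower number from compound 3 to compound 4 (0.08 log units; within the scatter), with no shift beyond the scatter anticipated. For compound 4 the estimated value is 13500 nM, with an expected range of 7000 nM to 25000 nM.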

Compound 4, half-maximal inhibitory concentration: 99900 nM
Beside the measured number, compound 4's estimate is 7.4-fold (0.87 log units) below it; measured number outside the range, above it.
By their numbers in this assay, from the lowest: compound 2; then compounds 3 and 1 (each within the scatter of the next); then compound 4.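

In this assay, among these compounds, the group on this phenyl ring can move the number up as well as down: methoxy in place of hydrogen gives a 5.8-fold higher number from compound 1 to compound 4 (0.77 log units; beyond the scatter), and methoxy in place of trifluoromethyl gives a 14-fold higher number from compound 2 to compound 4 (1.14 log units; beyond the scatter), the only large step. The 4-methoxyphenyl swap likewise gives a 6.1-fold higher number from compound 3 to compound 4 (0.79 log units; beyond the scatter). No measured finding accounts for this rise.

Going by these compounds, whether the rise is specific to methoxy remains open. An amine, a hydroxyl group or a longer chain such as ethoxy on this phenyl ring would help to settle that.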